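Urea-linked quinoline series: halogen swap on the terminal aryl ring

A few compounds are considered here, and "the series" means these few. Any claim that something is new, unique, unknown or untested is made for them only; others in the source may bear on it.

Measured compounds:
compound 1 `COc1cc2cc(Oc3ccc(NC(=O)Nc4cccc(C(F)(F)F)c4)cc3)c(C)nc2cc1OC` — 1630 nM
compound 2 `COc1cc2cc(Oc3ccc(NC(=O)Nc4ccc(Cl)c(C(F)(F)F)c4)cc3)c(C)nc2cc1OC` — 1330 nM

In a functional assay on RXF 393 cells (Homo sapiens) for inhibition, read by sulforhodamine B assay, with a stated time of 48 h (on this read-out higher numbers stand for weaker inhibition of growth and lower numbers for stronger inhibition of growth), compound 1 gives 1630 nM and compound 2 gives 1330 nM. Compound 2 holds the lower of the two numbers, but the step of a 1.2-fold lower number from compound 1 to compound 2 (0.09 log units; within the scatter) is within the scatter, so the two compounds cannot be told apart on this read-out.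

Compound 3 `COc1cc2cc(Oc3ccc(NC(=O)Nc4ccc(Cl)c(Cl)c4)cc3)c(C)nc2cc1OC` has not been measured. It differs from compound 2 by chloro in place of trifluoromethyl on an aromatic carbon. For the measured compounds named here, no measured step in this set changes the trifluoromethyl group; the only step available, a 1.2-fold lower number from compound 1 to compound 2 (0.09 log units; within the scatter), concerns the neighbouring chloro and was within the scatter. Going by the values given here, that step offers little guidance on the present change, and the series so far shows no movement beyond the scatter on this read-out.

The expectation is therefore that compound 3 stays close to compound 2, with a step of a 1.1-fold higher number from compound 2 to compound 3 (0.05 log units; within the scatter) expected and no change beyond the scatter. Compound 3 is estimated at 1500 nM, with a range of 500 nM to 4500 nM.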

Compound 3, concentration for 50% growth inhibition: 4280 nM
Estimate against measurement, compound 3: 2.9-fold (0.46 log units) below, and the stated range covers the measured number.
By their numbers in this assay, from the lowest: compounds 2 and 1 (each within the scatter of the next); then compound 3.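

Unlike the chloro in place of hydrogen, which gave a 1.2-fold lower number from compound 1 to compound 2 (0.09 log units; within the scatter), replacing trifluoromethyl with chloro produces a modest movement beyond the scatter in this assay, with a 3.2-fold higher number from compound 2 to compound 3 (0.51 log units; beyond the scatter) on the same read-out. The comparison with the unchlorinated parent points the same way: 3,4-dichlorophenyl in place of 3-(trifluoromethyl)phenyl on the amide-type nitrogen gives a 2.6-fold higher number from compound 1 to compound 3 (0.42 log units; beyond the scatter), so both compounds carrying trifluoromethyl inhibit growth more strongly than the dichloro compound, and this position tolerates the change less well than the earlier hydrogen-to-chloro step suggested. Nothing available here accounts for the weaker growth inhibition that comes with the loss of trifluoromethyl.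

Still open, from the compounds shown here alone, is whether trifluoromethyl is specifically favoured at this position or chloro is specifically poor there, a question that a nitrile, a methoxy group or a dimethylamino group at the same place would help settle. Going by these compounds, it also remains open whether the step from trifluoromethyl to chloro keeps its size without the second chloro on the ring.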